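A few compounds are considered here, and "the series" means these few. Any claim that something is new, unique, unknown or untested is made for them only; others in the source may bear on it.

Working notes on the series. The read-out throughout is a physicochemical assay for acid dissociation. Three compounds have numbers. Compound 1 `COc1ccccc1Oc1ccc2c(NCCCNCc3ccco3)ccnc2c1` gives 9.28 in this assay. Compound 2 `COc1cccc(CNCCCNc2ccnc3cc(Cc4ccccc4)ccc23)c1O` gives 9.47. Compound 3 `COc1cccc(CNCCCNc2ccnc3cc(-c4cc(C(F)(F)F)cc(C(F)(F)F)c4)ccc23)c1O` gives 9.47. Compound 1 sits at the lowest of the three numbers, but its separation from compound 2 and from compound 3 lies within the scatter, so the three values cannot be ordered and are taken as one level. Compounds 2 and 3, which differ from each other in the group on the core, also sit within the scatter of each other.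

Compound 4 `COc1ccc(Oc2ccc3c(NCCCNCc4ccco4)ccnc3c2)cc1` is not yet measured. It differs from compound 1 only in one place: 4-methoxyphenyl in place of 2-methoxyphenyl on an oxygen on an aromatic ring. Going by the values given here, no pair of measured compounds shows this or any single step, so the size of the step can only be judged from the spread of the three measured numbers, which is flat. The expectation for compound 4 is therefore no step beyond the scatter from compound 1, in either direction, and the step of a number 0.02 log units higher from compound 1 to compound 4 (within the scatter) is estimated as essentially flat. In this assay compound 4 is expected to give 9.3, within a range from 9 to 9.6.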

Compound 4, acid dissociation constant: 9.28
Estimate against measurement, compound 4: 0.02 log units above; the range from low to high includes it.
By their numbers in this assay, from the lowest: compounds 1, 4, 2 and 3 (each within the scatter of the next).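

Going by these compounds alone, this is the first pair that differs in one place only, so the swap can now be read directly rather than judged from the spread of unrelated compounds. In this assay, 4-methoxyphenyl in place of 2-methoxyphenyl on an oxygen on an aromatic ring gives no change at the digits printed from compound 1 to compound 4 (within the scatter), so at this position the read-out does not separate the two methoxyphenyl groups, which have the same atoms joined differently. This holds for this one swap on the core of compound 1, and nothing on hand gives a reason for the flat step.

Both groups carry a methoxy group, so the pair says nothing about how the read-out responds when the group on this oxygen changes in kind, for example with an amine or a carboxylic acid on the phenyl ring in place of the methoxy group. On these data alone, it also remains open whether the same swap would be equally flat with another group on the side chain of compound 4, such as a longer chain between the two nitrogens.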